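A few compounds are considered here, and "the series" means these few. Any claim that something is new, unique, unknown or untested is made for them only; others in the source may bear on it.

Measured so far in a functional assay on L1210 cells (Mus musculus) for inhibition (on this read-out lower numbers stand for an effect already at smaller amounts and higher numbers for an effect only at larger amounts of compound), are three compounds:

- Compound 1 `N[C@@H]1C[C@H](n2cc(F)c(=O)[nH]c2=O)O[C@@H]1CO` (15 uM)
- Compound 2 `[N-]=[N+]=N[C@H]1C[C@H](n2cc(F)c(N)nc2=O)O[C@@H]1CO` (25 uM)
- Compound 3 `Nc1ccn([C@H]2C[C@H](N)[C@@H](CO)O2)c(=O)n1` (0.7 uM)

Compound 1 stands at the upper end of this small set. Its number lies within the usual scatter of that of compound 2, so the two cannot be told apart. Compound 3 shows a clearly lower number than either of them, and thus an effect at smaller amounts.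

Compound 4 `N[C@@H]1C[C@H](n2cc(C(F)(F)F)c(=O)[nH]c2=O)O[C@@H]1CO` has not yet been measured. It carries trifluoromethyl in place of fluoro on an aromatic carbon of the core of compound 1 (trifluoromethyl in place of fluoro on an aromatic carbon). Going by the values given here, no two measured compounds differ in one place only, so the data offer no direct measure of this or any similar change. The expectation therefore rests on compound 1 (15 uM) as its only anchor, and its direction is a judgement rather than a measured trend.

A modest move toward a higher number is expected in this assay, close to the limit of the usual scatter. The expected shift is a 2.0-fold higher number from compound 1 to compound 4 (0.30 log units; within the scatter) on this estimate. The estimated value for compound 4 is 30 uM with an expected range from 8 uM to 100 uM around it.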

Compound 4, concentration for half-maximal effect: 150 uM
The estimate for compound 4 lay 5.0-fold (0.70 log units) below the measured number, outside the stated range (above it).
By their numbers in this assay, from the lowest: compound 3; then compounds 1 and 2 (each within the scatter of the next); then compound 4.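

In this assay, going by these compounds alone, the replacement of fluoro by trifluoromethyl on this aromatic carbon of the six-membered aromatic ring with 2 nitrogen provides the first step between two compounds that differ in one place only: a 10-fold higher number from compound 1 to compound 4 (1.00 log units; beyond the scatter), beyond the scatter. The read-out at this position therefore responds clearly to going from a group of 1 heavy atom to one of 4 heavy atoms, although neither group carries a hydrogen-bond donor, a hydrogen-bond acceptor or a net charge. Nothing available on these compounds bears on the reason for this rise, so the step stands as an observation only.

A single step cannot show whether the number follows the count of heavy atoms in the group at this carbon, and a methyl group, a chlorine atom or a plain hydrogen there would each give a further point on that question. On these data alone, it also remains open whether the same replacement would have a similar effect on the core of compound 3, which carries an amino group on its ring.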